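Swapping a benzyl substituent on a triazole-linked pyrimidine

A few compounds are considered here, and "the series" means these few. Any claim that something is new, unique, unknown or untested is made for them only; others in the source may bear on it.

Measured in a functional assay on B16-F10 cells (Mus musculus) for inhibition, read by MTT assay, with a stated time of 72 h; on this read-out lower numbers stand for stronger inhibition and higher numbers for weaker inhibition:
- compound 1 `N#Cc1c(Nc2ccccc2F)nc(SCc2cn(Cc3ccccc3Cl)nn2)nc1-c1ccccc1`: 5230 nM
- compound 2 `Cc1ccc(Cn2cc(CSc3nc(Nc4ccccc4F)c(C#N)c(-c4ccccc4)n3)nn2)cc1`: 16000 nM
- compound 3 `Cc1ccc(Cn2cc(CSc3nc(Nc4ccc(C)cc4)c(C#N)c(-c4ccccc4)n3)nn2)cc1`: 8160 nM

Compound 4 `Cc1ccc(Nc2nc(SCc3cn(Cc4ccccc4Cl)nn3)nc(-c3ccccc3)c2C#N)cc1` has not yet been measured in this assay. It is built from compound 3 by one change: 2-chlorophenyl in place of 4-methylphenyl on a saturated chain carbon bound to an aromatic nitrogen. The same change has already been made once among the measured compounds, from compound 2 to compound 1, where it reads 2-chlorophenyl in place of 4-methylphenyl on a saturated chain carbon bound to an aromatic nitrogen and gave a 3.1-fold lower number from compound 2 to compound 1 (0.49 log units; beyond the scatter). The place of the change is described in the same words in both pairs, so this is the same change and not merely the same kind of change.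

The two starting points, compound 2 and compound 3, differ in their cores by 4-methylphenyl in place of 2-fluorophenyl on a nitrogen on an aromatic ring, a change that gave a 2.0-fold lower number from compound 2 to compound 3 (0.29 log units; within the scatter), which is within the usual scatter, so the two cores cannot be told apart by their numbers. Among the measured compounds shown here, with only one earlier example of the change and two cores that look alike in this assay, the expectation for compound 4 is a step of about a 2.6-fold lower number from compound 3 to compound 4 (0.41 log units; beyond the scatter), a little smaller than the earlier one because the earlier step of a 3.1-fold lower number from compound 2 to compound 1 (0.49 log units; beyond the scatter) rests on a single pair.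

Compound 4 is therefore estimated to give 3200 nM in this assay, with a likely range from 1300 nM to 7500 nM.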

Compound 4, half-maximal inhibitory concentration: 3390 nM
For compound 4 the middle estimate is 1.1-fold (0.03 log units) below the measured one, within the range that was stated.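

In this assay, putting 2-chlorobenzyl in place of 4-methylbenzyl gave a 2.4-fold lower number from compound 3 to compound 4 (0.38 log units; beyond the scatter), and this step agrees with the one seen earlier on the other core: the same change on two cores in this assay, a 3.1-fold lower number (0.49 log units; beyond the scatter) from compound 2 to compound 1 and a 2.4-fold lower number (0.38 log units; beyond the scatter) from compound 3 to compound 4, 1.3-fold (0.10 log units) apart, within the scatter of two such steps. The change on the other side of the molecule, 4-methylphenyl in place of 2-fluorophenyl on a nitrogen on an aromatic ring, gave a 1.5-fold lower number from compound 1 to compound 4 (0.19 log units; within the scatter), a step too small to read as a real difference, and it looks alike with either benzyl group: the same change on two cores in this assay, a 2.0-fold lower number (0.29 log units; within the scatter) from compound 2 to compound 3 and a 1.5-fold lower number (0.19 log units; within the scatter) from compound 1 to compound 4, 1.3-fold (0.10 log units) apart, within the scatter of two such steps. So the benzyl swap carried over from one core to another here, but this rests on just two pairs whose cores differ in one group, and it shows neither why the number falls nor whether the swap would carry over to a more different core.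

Going by these compounds, it remains open how a plain benzyl, a 4-chlorobenzyl or a 2-methylbenzyl group would compare. The data do not separate the presence of the chlorine from where it sits on the ring. Also open, on these data alone, is whether the step would hold with an amine or a carboxylic acid in place of the 4-methylphenyl or 2-fluorophenyl group, or in any read-out other than this assay.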